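A few compounds are considered here, and "the series" means these few. Any claim that something is new, unique, unknown or untested is made for them only; others in the source may bear on it.

- compound 1 `C#CCSc1nc(Nc2ccccc2)c2ccncc2n1`: > 80000 nM
- compound 2 `C#CCSc1nc(Nc2ccccc2OC)c2ccncc2n1`: > 80000 nM

The measurements come from a functional assay on PC-3 cells (Homo sapiens) for inhibition, read by MTT assay, with a stated time of 72 h; on this read-out lower numbers stand for stronger inhibition and higher numbers for weaker inhibition. On this read-out, compound 1 gives only a limit, > 80000 nM, and not an exact number. Compound 2 also gives only a limit, > 80000 nM.

Compound 3 `C#CCSc1nc(Nc2cccc(OC)c2)c2ccncc2n1` has not yet been measured. Its difference from compound 1 is methoxy in place of hydrogen on an aromatic carbon. Among the compounds with values here, the one measured step that bears on this change is also a swap of hydrogen for methoxy on an aromatic carbon: a step that the two limits leave unreadable from compound 1 to compound 2. Both measured compounds share the same ceiling: the limit of > 80000 nM in this assay, at which 2 of the 2 values shown sit. From the compounds shown here alone, neither the size nor the direction of that step can therefore be read, and the true potency of compound 1 remains unknown.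

With no measured gain from the earlier methoxy swap, no step beyond the scatter is expected in this assay. The expected step is a number no higher from compound 1 to compound 3 (the limit leaves the size open). For compound 3 the estimated value is 80000 nM, with an expected range of 30000 nM to 150000 nM.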

Compound 3, half-maximal inhibitory concentration: 17100 nM
Estimate against measurement, compound 3: 4.7-fold (0.67 log units) above; measured number below the stated range.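

In this assay, methoxy in place of hydrogen on an aromatic carbon, meta to a large group, brings an at least 4.6-fold lower number from compound 1 to compound 3 (0.67 log units; beyond the scatter). This is the first change among the compounds shown whose step can be read, and it shows that the number can respond to a change at this place on the six-membered aromatic ring, whereas the step to compound 2, which carries the same group placed differently, cannot be read. The size of the new step stands only as a minimum because compound 1 gives a limit and not an exact number: the limit of > 80000 nM in this assay, at which 2 of the 3 values shown sit.

The compounds shown leave open whether methoxy itself matters at this place, or whether another group there, such as an amine, a carboxylic acid or a longer chain like ethoxy, would give a lower number still. They also leave open how large the step truly is, and whether adding a second group to compound 3 at another place on the same ring would lower the number further or raise it again.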